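A few compounds are considered here, and "the series" means these few. Any claim that something is new, unique, unknown or untested is made for them only; others in the source may bear on it.

The measured compounds and their numbers in a functional assay on L1210 cells (Mus musculus) for antiproliferative activity; a lower number here means a less potent compound, a higher number a more potent compound, by a factor of ten per unit of this negative logarithm:

compound 1, `CN(C)/N=N/c1n[nH]cc1C(N)=O`, gives 3.49
compound 2, `C=CCN(C)/N=N/c1n[nH]cc1C(N)=O`, gives 3.77
compound 3, `CN(C)/N=N/c1ccc(NC(N)=O)cc1`, gives 3.97

Compound 1 and compound 2 share one core, and compound 3 has another; the difference between the two cores is not broken down here. Compound 2 differs from compound 1 in a single place: vinyl in place of hydrogen on a saturated chain carbon bound to an amine nitrogen. In this assay this change produced a number 0.28 log units higher from compound 1 to compound 2 (within the scatter), so the two values are within the scatter of each other.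

Compound 4, `C=CCN(C)/N=N/c1ccc(NC(N)=O)cc1`, is not yet measured. It carries the same change, made on compound 3 instead of compound 1: vinyl in place of hydrogen on a saturated chain carbon bound to an amine nitrogen. Both changes sit at the same kind of place, so the only thing that differs between the two pairs is the core.

Among the compounds with values here, the one measured example of this change gave a small step, and a step of about that size is expected again for compound 4, a number 0.28 log units higher from compound 3 to compound 4 (within the scatter), because a number 0.28 log units higher from compound 1 to compound 2 (within the scatter) was small. Starting from compound 3, compound 4 is therefore estimated at 4.25 in this assay, with a likely range from 3.8 to 4.7.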

Compound 4, logarithm of the reciprocal of the active concentration, log(1/C): 3.77
Estimate against measurement, compound 4: 0.48 log units above; the measured number lies below the stated range.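

In this assay the same change, vinyl in place of hydrogen on a saturated chain carbon bound to an amine nitrogen, gave a number 0.20 log units lower from compound 3 to compound 4 (within the scatter) and so did not repeat the step seen on the core of compound 1, although each step taken alone stays within the usual scatter. Set side by side, the two steps do differ, so in this small set the step measured on one core cannot simply be carried over to the other: the same change on two cores in this assay, a number 0.28 log units higher (within the scatter) from compound 1 to compound 2 and a number 0.20 log units lower (within the scatter) from compound 3 to compound 4, 0.48 log units apart, beyond the scatter of two such steps

These two pairs alone do not show why the steps differ, nor how the change would behave on a third core.

The compounds shown leave open whether the two cores would also part ways with a propyl group, the saturated chain of the same length as allyl, in its place on the nitrogen. They also leave open what a longer chain, such as butyl, would do on each core.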